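Amide aryl swap on the shared core

This account rests on a few compounds, and the source may have more. Where it says the series, first, only, none or still open, it means among the compounds named here.

compound 1 `CC(=O)Nc1ccc([N+](=O)[O-])cc1OCc1ccccc1` 1180 nM
compound 2 `O=C(Nc1ccc([N+](=O)[O-])cc1OCc1ccccc1)c1ccc(Cl)c(Cl)c1` > 25000 nM

In an assay on SK-BR-3 cells for inhibition of Aromatase (Homo sapiens) (on this read-out lower numbers stand for stronger inhibition and higher numbers for weaker inhibition), compound 1 gives 1180 nM. For compound 2 the value > 25000 nM is a limit of the assay, not a number (the limit of > 25000 nM in this assay, at which 1 of the 2 values shown sits). Within the data shown here, the one measured step, an at least 21-fold higher number from compound 1 to compound 2 (1.32 log units; beyond the scatter), shows that an aryl amide sits at or past that limit. Compound 3 `O=C(Nc1ccc([N+](=O)[O-])cc1OCc1ccccc1)c1ccc2ccccc2c1` carries naphthalen-2-yl in place of 3,4-dichlorophenyl on a carbonyl carbon. Among the measured compounds shown here, no measured step covers an exchange of one aryl group for another, so the weak footing of compound 2 is the only anchor. Compound 3 is therefore expected near the same limit, at 20000 nM within 4000 nM to 60000 nM. The expected step is an at least 1.2-fold lower number from compound 2 to compound 3 (0.09 log units; that floor lies within the scatter), nothing beyond the scatter.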

Compound 3, half-maximal inhibitory concentration: > 25000 nM
Compound 3: no number, only a limit; the forecaster's own chance of this, stated with the estimate: 55%; middle value at least 1.2-fold (0.09 log units) from the limit.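

Replacing methyl with naphthalen-2-yl on the carbonyl carbon (an at least 21-fold higher number from compound 1 to compound 3 (1.32 log units; beyond the scatter)) shows that the large loss is not confined to 3,4-dichlorophenyl. The value for compound 3 is a limit, as is the value for compound 2, so the step between them cannot be read and the two aryl groups cannot be ranked. Both aryl amides therefore sit at the same assay limit: the limit of > 25000 nM in this assay, at which 2 of the 3 values shown sit.

Still open, on these data alone, is whether ethyl, cyclopropyl or unsubstituted phenyl on the carbonyl carbon would give a readable number. A basic amine or a carboxylic acid in that place also remains untested in the compounds shown here.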